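The source may report more compounds than this note shows. Statements on the series, on what has been measured and on what is new or still open speak of the compounds shown alone.

Three related sulfonamides have been tested in an assay on cells for inhibition of HSP60/HSP10 (Homo sapiens), with a stated time of 60 min (on this read-out lower numbers stand for stronger inhibition and higher numbers for weaker inhibition), and none of them reaches a strong reading. Compound 1 `O=S(=O)(Nc1ccc(-c2nc3ccccc3o2)cc1)c1ccccc1Cl` carries a 2-chlorophenyl on its sulfonyl sulfur. In this assay compound 1 stops at > 100000 nM, which is a limit of the assay rather than a number. Compound 2 `O=S(=O)(Nc1ccc2oc(-c3ccccc3)nc2c1)c1cccc(O)c1` gives 76000 nM in this assay. Compound 3 `COc1ccc(S(=O)(=O)Nc2ccc3oc(-c4ccccc4)nc3c2)cc1` likewise stops at the limit > 100000 nM in this assay. Within the data shown here, the only step between measured compounds that differ in one place, an at least 1.3-fold higher number from compound 2 to compound 3 (0.11 log units; that floor lies within the scatter), exchanges the group on the sulfonyl sulfur and moves the reading no further than the scatter; its size is bounded by the limit of > 100000 nM in this assay, at which 2 of the 3 values shown sit. The unmeasured compound 4 `C=Cc1ccc(S(=O)(=O)Nc2ccc(-c3nc4ccccc4o3)cc2)cc1` differs from compound 1 in one place: 4-vinylphenyl in place of 2-chlorophenyl on a sulfonyl sulfur. Among the measured compounds shown here, this exchange has no measured counterpart, and with compound 1 standing at the limit the direction of any shift cannot be read from the numbers, so no step beyond the scatter is expected in this assay. Compound 4 is therefore estimated to remain weak, near 100000 nM, with an expected range from 30000 nM to 300000 nM. The step this estimate implies, a number no higher from compound 1 to compound 4 (the limit leaves the size open), is expected to be small.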

Compound 4, half-maximal inhibitory concentration: > 100000 nM
Compound 4 was reported as a limit (the forecaster's own chance of this, stated with the estimate: 65%); the middle value sits exactly at the limit.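

No step can be read from compound 1 to compound 4 in this assay, because each of the two compounds stops at a limit of the assay rather than a number: the limit of > 100000 nM in this assay, at which 3 of the 4 values shown sit.

The compounds shown leave open how 2-chlorophenyl and 4-vinylphenyl truly compare, and whether any group on the sulfonyl sulfur gives the core of compound 1 a reading that is a number.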